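The source may report more compounds than this note shows. Statements on the series, on what has been measured and on what is new or still open speak of the compounds shown alone.

For the measured compounds named here, compound 1 `COc1ccc([C@@H]2CC(=O)c3c(O)cc(OCc4cn(Cc5ccccc5)nn4)cc3O2)cc1O` stands at the top of the two numbers known so far. In a functional assay on RAW264.7 cells (Mus musculus) for inhibition, read by Griess assay, with stated times of 2 h and 24 h (on this read-out lower numbers stand for stronger inhibition and higher numbers for weaker inhibition), compound 1 gives 11000 nM, the highest number of the pair and therefore the weaker inhibition. Going by the values given here, the only other measured compound, compound 2 `CCCn1cc(COc2cc(O)c3c(c2)O[C@H](c2ccc(OC)c(O)c2)C/C3=N\O)nn1`, gives in this assay 2340 nM, a lower number that lies beyond the usual scatter of the read-out. Compound 2 differs from compound 1 in several places at once, so it tells nothing about any single change.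

The new compound, compound 3 `COc1ccc([C@@H]2CC(=O)c3c(O)cc(OCc4cn(Cc5cccc(C#N)c5)nn4)cc3O2)cc1O`, differs from compound 1 in one place only: cyano in place of hydrogen on an aromatic carbon. Among the compounds with values here, no measured pair in this set shows what such a substitution does on this core, so the expectation rests on the size of the change alone. The step of a 1.4-fold lower number from compound 1 to compound 3 (0.14 log units; within the scatter) is expected to be small and probably toward a lower number, without confidence that it leaves the scatter. Compound 3 is therefore estimated to give 8000 nM in this assay, with a range from 3000 nM to 20000 nM.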

Compound 3, half-maximal inhibitory concentration: 18000 nM
Beside the measured number, compound 3's estimate is 2.3-fold (0.35 log units) below it, within the range that was stated.
By their numbers in this assay, from the lowest: compound 2; then compounds 1 and 3 (each within the scatter of the next).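

For the compounds shown here, the step from benzyl to 3-cyanobenzyl is the first single change that can be read in this set, and in this assay it amounts to a 1.6-fold higher number from compound 1 to compound 3 (0.21 log units; within the scatter). Cyano in place of hydrogen at this aromatic carbon, meta to a large group, therefore gives no change that can be told apart from repeated measurement, and compounds 1 and 3 cannot be ranked against each other. This position on the outer six-membered aromatic ring carries the added nitrile without a shift beyond the scatter in this read-out, though that is one group at one place, and no separate measurement bears on why the result reads this way.

The compounds shown leave open whether an amine, a carboxylic acid or a methoxy group on this same aromatic carbon would move the number beyond the scatter, and what a longer chain in place of the benzyl group would do on the core of compound 1. They also leave open which of the several differences in compound 2 accounts for its number, since no single step connects it to the others.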